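This account rests on a few compounds, and the source may have more. Where it says the series, first, only, none or still open, it means among the compounds named here.

Compound 1 `COC(=O)CC/C(C)=C/Cc1c(OC)c(C)c2c(c1OCC#CCN1CCN(c3ccc(C#N)cc3)CC1)C(=O)OC2`: 37800 nM
Compound 2 `COC(=O)CC/C(C)=C/Cc1c(OC)c(C)c2c(c1OCC#CCN1CCN(Cc3ccc(Cl)cc3)CC1)C(=O)OC2`: 31200 nM
Compound 3 `COC(=O)CC/C(C)=C/Cc1c(OC)c(C)c2c(c1OCC#CCN1CCN(C(c3ccccc3)c3ccc(Cl)cc3)CC1)C(=O)OC2`: 9900 nM

These values come from a functional assay on SH-SY5Y cells (Homo sapiens) for inhibition, read by sulforhodamine B assay; a lower number here means a stronger inhibitor, a higher number a weaker inhibitor. Among the three, compound 3 has the lowest number, at 9900 nM. Compound 4 `COC(=O)CC/C(C)=C/Cc1c(OC)c(C)c2c(c1OCC#CCN1CCN(C(c3ccccc3)c3ccccc3)CC1)C(=O)OC2` differs from it in one place: hydrogen in place of chloro on an aromatic carbon.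

Going by the values given here, no measured step tests this chloro. The closest evidence is a 3.2-fold lower number from compound 2 to compound 3 (0.50 log units; beyond the scatter), with phenyl in place of hydrogen on the saturated chain carbon, and compound 4 keeps that phenyl. The other step, a 1.2-fold lower number from compound 1 to compound 2 (0.08 log units; within the scatter), exchanged a whole substituent. A change within the scatter is therefore expected, with any drift towards a slightly higher number.

The expected step is a 1.2-fold higher number from compound 3 to compound 4 (0.08 log units; within the scatter). Compound 4 is estimated at 12000 nM, with an expected range of 6000 nM to 25000 nM.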

Compound 4, half-maximal inhibitory concentration: 23700 nM
Compound 4: the middle estimate sits 2.0-fold (0.30 log units) below what was measured; low and high end bracket the measured number.
By their numbers in this assay, from the lowest: compound 3; then compounds 4, 2 and 1 (each within the scatter of the next).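

In this assay, the change from 4-chlorophenyl to phenyl gives a 2.4-fold higher number from compound 3 to compound 4 (0.38 log units; beyond the scatter), so this single chlorine, para to a large group, makes a difference beyond the scatter on its own. Going by these compounds alone, the earlier steps tested only a whole-substituent exchange and the added phenyl on the chain carbon; this is the first to isolate the chloro. Nothing available explains the size of this step. From the compounds shown here alone, it remains open whether chloro is specifically required here, or whether fluoro, bromo, methyl or methoxy in the same place would serve equally. Going by these compounds, the effect of a chloro on the other phenyl ring also remains unknown.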